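The source may hold more compounds than are shown below. What is called first, only, known or untested is meant among the compounds shown, and "the series" means these compounds.

Two related diols have so far been measured in a functional assay on U-937 cells (Homo sapiens) for antiproliferative activity, read by MTT assay, with a stated time of 48 h; a higher number here means a weaker inhibitor, a lower number a stronger inhibitor. Compound 1, `O[C@H](CCc1ccccc1)C[C@@H](O)CCc1ccccc1`, gives 188 ug/mL in this assay. Compound 2, `Oc1ccc(CC[C@H](O)C[C@@H](O)CCc2ccccc2)cc1`, gives 31.1 ug/mL in this assay, the lowest of the two numbers, with compound 1 standing a good deal higher and well beyond the usual scatter. Compound 3, `Oc1ccc(CC[C@@H](O)C[C@@H](O)CCc2ccccc2)cc1`, has not yet been measured. Its difference from compound 2 is a matter of configuration alone: the two compounds have the same atoms and bonds and differ only in configuration as drawn: 1 of 2 stereo elements differ; a stereocentre at a saturated chain carbon is drawn S in compound 2 and R in compound 3. Among the compounds with values here, no measured pair in this set shows what such a change of configuration does to the number, so there is no step to gauge it by. A modest weakening, a 1.6-fold higher number from compound 2 to compound 3 (0.21 log units; within the scatter), is expected for compound 3, while allowing that a change of this kind could also leave the number within the scatter or shift it the other way. Compound 3 is therefore estimated at 50 ug/mL in this assay, with a range from 15 ug/mL to 160 ug/mL.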

Compound 3, half-maximal inhibitory concentration: 33 ug/mL
Compound 3: middle estimate off by 1.5-fold (0.18 log units), on the high side; measured number inside the range.
By their numbers in this assay, from the lowest: compounds 2 and 3 (each within the scatter of the next); then compound 1.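

Changing the configuration at this saturated chain carbon gives a 1.1-fold higher number from compound 2 to compound 3 (0.03 log units; within the scatter) in this assay, so the assay does not distinguish the two forms at this stereocentre. This comparison isolates that single stereocentre, because nothing else separates the two compounds: the fact that compounds 2 and 3 differ only in the configuration as drawn. Hydroxy in place of hydrogen on an aromatic carbon gives a 5.7-fold lower number from compound 1 to compound 3 (0.76 log units; beyond the scatter), which shows that the lower number that comes with this group also holds with the stereocentre drawn R, and not only with it drawn S as in compound 2.

The compounds shown vary only one of the two stereocentres, so the effect of changing the other remains open. Also open, as far as these compounds go, is whether a methoxy or an amino group in place of the aromatic hydroxy would keep the lower number.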